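One more methoxy on compound 1

This account rests on a few compounds, and the source may have more. Where it says the series, first, only, none or still open, it means among the compounds named here.

compound 1 `COc1ccc(-c2nc(N3CCNCC3)nc3ccccc23)c(OC)c1` gives 50 ug/mL
compound 2 `c1ccc2c(c1)ccn2-c1nc(N2CCNCC2)nc2ccccc12` gives 12.5 ug/mL
compound 3 `c1ccc2c(c1)ccn2-c1nc(N2CCCCC2)nc2ccccc12` gives 50 ug/mL

In a functional assay on DU-145 cells (Homo sapiens) for antiproliferative activity, read by MTT assay (a lower number here means a stronger inhibitor, a higher number a weaker inhibitor), compound 1 gives 50 ug/mL and stands level with compound 3 at the digits shown, the two sharing the highest of the three numbers. Compound 2 gives the lowest number at 12.5 ug/mL and lies clearly apart from them.

Compound 4 `COc1cc(OC)c(-c2nc(N3CCNCC3)nc3ccccc23)c(OC)c1` has not yet been measured. It departs from compound 1 by a single change, methoxy in place of hydrogen on an aromatic carbon and the rest of the structure stays the same.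

Among the measured compounds shown here, no measured step adds a methoxy group. The only one available, a 4.0-fold higher number from compound 2 to compound 3 (0.60 log units; beyond the scatter) in this assay and described as modest, is piperidin-1-yl in place of piperazin-1-yl on an aromatic carbon. That is a different change at a different place, so it serves only as a rough gauge of how far one change has moved these numbers. The direction of the new step therefore cannot be read from the data, and no shift beyond the scatter is expected. The expected step is no change at the digits printed from compound 1 to compound 4 (within the scatter) as estimated here. For compound 4 the estimated value is 50 ug/mL with an expected range from 20 ug/mL to 110 ug/mL in this estimate.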

Compound 4, half-maximal inhibitory concentration: 50 ug/mL
The estimate for compound 4 equals the measured number at the digits printed; the range from low to high includes it.
By their numbers in this assay, from the lowest: compound 2; then compounds 1, 3 and 4 (each within the scatter of the next).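

In this assay, methoxy in place of hydrogen on an aromatic carbon, at a place ortho to a large group and meta to two methoxy groups, brings no change at the digits printed from compound 1 to compound 4 (within the scatter). Among the compounds shown here, the one earlier step, a 4.0-fold higher number from compound 2 to compound 3 (0.60 log units; beyond the scatter), concerned piperazin-1-yl, so it said nothing about this ring; this new step shows that, in this assay, the ring of compound 1 can carry a methoxy group at this place without a shift beyond the scatter. No measurement at hand bears on why the number holds here.

Going by these compounds, whether another group at this place, such as an amine, a carboxylic acid or a longer chain such as butoxy, would leave the number where it stands remains open. Also open, on these data alone, is whether the same methoxy would give the same result on a compound carrying piperidin-1-yl in place of piperazin-1-yl, and whether any change to this ring could bring the number down to the level of compound 2, at 12.5 ug/mL.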